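This account rests on a few compounds, and the source may have more. Where it says the series, first, only, none or still open, it means among the compounds named here.

Compound 1 `CCOc1ccc(-n2nncc2CN2C(=O)C3(C(C#N)=C(N)Oc4c3c3nc5ccccc5nc3c3ccccc43)c3ccccc32)cc1` — > 50000 nM
Compound 2 `COc1ccc(-n2nncc2CN2C(=O)C3(C(C#N)=C(N)Oc4c(N)cc5nc6ccccc6nc5c43)c3ccccc32)cc1` — > 50000 nM

In a functional assay on HepG2 cells (Homo sapiens) for antiproliferative activity, read by MTT assay, with a stated time of 48 h (a higher number here means a weaker inhibitor, a lower number a stronger inhibitor), compound 1 gives > 50000 nM, which is a limit of the assay rather than a number. Compound 2 gives > 50000 nM, likewise a limit. Going by the values given here, compound 2 therefore stands at the limit, as does the only other value shown: the limit of > 50000 nM in this assay, at which 2 of the 2 values shown sit. Compound 3 `N#CC1=C(N)Oc2c(N)cc3nc4ccccc4nc3c2C12C(=O)N(Cc1cnnn1-c1ccc(Cl)cc1Cl)c1ccccc12` differs from compound 2 by 2,4-dichlorophenyl in place of 4-methoxyphenyl on an aromatic nitrogen. Among the compounds with values here, no step between measured compounds is available, so the data give no size for any change of this kind, and with both values at the limit there is no number to move from. Compound 3 is expected to give about 60000 nM, with a range from 20000 nM to 200000 nM. The step that the limit leaves unreadable from compound 2 to compound 3 is expected to be none beyond the scatter, and the most likely outcome is that the assay again reports only a limit.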

Compound 3, half-maximal inhibitory concentration: > 50000 nM
Compound 3: only a limit was reported; the forecaster's own chance of this, stated with the estimate: 75%; the middle value does not contradict the limit.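

No step can be read from compound 2 to compound 3, because in this assay both compounds give only a limit of the assay, not a number: the limit of > 50000 nM in this assay, at which 3 of the 3 values shown sit. The compounds shown leave open how they rank and whether any change to the shared core would give a measurable value in this assay.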